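Swapping chloro for methyl on a sulfonyl-anilide core

The source may hold more compounds than are shown below. What is called first, only, known or untested is meant among the compounds shown, and "the series" means these compounds.

Three close relatives of one amide have been tested in a functional assay (Cavia porcellus) with sulfonylurea receptors; K-ATP channels (Homo sapiens) as the target; a lower number here means a stronger inhibitor, a higher number a weaker inhibitor. They share a core in which a trifluoromethyl-bearing hydroxy-amide is attached to an aniline that also carries a phenylsulfonyl group, and they differ only in one small substituent on that aniline ring. Compound 1 `CC(O)(C(=O)Nc1ccc(S(=O)(=O)c2ccccc2)c(F)c1)C(F)(F)F` carries a fluoro there and gives 1800 nM in this assay. Compound 2 `CC(O)(C(=O)Nc1ccc(S(=O)(=O)c2ccccc2)c(C#N)c1)C(F)(F)F` carries a cyano and gives 3800 nM. Compound 3 `CC(O)(C(=O)Nc1ccc(S(=O)(=O)c2ccccc2)c(Cl)c1)C(F)(F)F` carries a chloro and gives 2200 nM, the second highest of the three numbers; its neighbours sit close on either side.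

The measured steps are small. There was a 1.2-fold higher number from compound 1 to compound 3 (0.09 log units; within the scatter), and a 1.7-fold lower number from compound 2 to compound 3 (0.24 log units; within the scatter); only a 2.1-fold higher number from compound 1 to compound 2 (0.32 log units; beyond the scatter) reached beyond the scatter. The change now considered is methyl in place of chloro on an aromatic carbon, giving compound 4 `Cc1cc(NC(=O)C(C)(O)C(F)(F)F)ccc1S(=O)(=O)c1ccccc1`. Among the measured compounds shown here, no measured step involves a methyl, so the only guide is that the three substituents tried so far moved the number little. Compound 4 is therefore expected to give about 2200 nM, with a plausible range from 1000 nM to 5000 nM. This estimate implies no change at the digits printed from compound 3 to compound 4 (within the scatter), a step expected to stay within the scatter.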

Compound 4, half-maximal inhibitory concentration: 1600 nM
Compound 4: middle estimate off by 1.4-fold (0.14 log units), on the high side, within the range that was stated.
By their numbers in this assay, from the lowest: compounds 4, 1, 3 and 2 (each within the scatter of the next, the first and the last beyond it).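

The methyl result extends the flat picture at this position, ortho to a group of 9 heavy atoms, to a substituent with a carbon in place of a halogen: in this assay, methyl in place of chloro gives a 1.4-fold lower number from compound 3 to compound 4 (0.14 log units; within the scatter) and methyl in place of fluoro gives a 1.1-fold lower number from compound 1 to compound 4 (0.05 log units; within the scatter), so compounds 1, 3 and 4 cannot be told apart. Methyl in place of cyano is a clearer step, with a 2.4-fold lower number from compound 2 to compound 4 (0.38 log units; beyond the scatter) as the largest gap among the four compounds, yet compound 2 remains within the scatter of compound 3, so the cyano compound does not stand wholly apart from the others. Nothing measured here offers an explanation for these numbers, so the data record only how little the read-out moves across these four groups.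

Fluoro, chloro, cyano and methyl cover a narrow set of groups, so it stays open whether a methoxy, an amine, a carboxylic acid or a longer chain at this position would leave the number in the same range. On these data alone, it is also open whether methyl and chloro would still match if the shared core were changed elsewhere.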